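Second cis double bond on the thioether-linked chain

A few compounds are considered here, and "the series" means these few. Any claim that something is new, unique, unknown or untested is made for them only; others in the source may bear on it.

Compound 2 `CCCCCCCC/C=C\CCCCCCCCSCCC(=O)NCc1ccc(O)c(OC)c1` holds the only number shown in an assay on HEK293 cells for antagonist activity at transient receptor potential cation channel subfamily V member 2 (Rattus norvegicus), read by fluorescence and calcium flux, with a stated time of 5 min; a higher number here means a weaker inhibitor, a lower number a stronger inhibitor; compound 2 gives 2500 nM. Compound 1 `CCCCCC[C@@H](O)C/C=C\CCCCCCCCSCCC(=O)NCc1ccc(O)c(OC)c1` reaches only a limit in this assay, > 10000 nM. The step of an at least 4.0-fold lower number from compound 1 to compound 2 (0.60 log units; beyond the scatter) rests on (the limit of > 10000 nM in this assay, at which 1 of the 2 values shown sits). Compound 3 `CCCCC/C=C\C/C=C\CCCCCCCCSCCC(=O)NCc1ccc(O)c(OC)c1` differs from compound 2 by hept-1-en-1-yl in place of heptyl on a saturated chain carbon bound to a double-bonded chain carbon. Going by the values given here, the single measured step concerns a hydroxy group, not a chain double bond, so it does not bear on this change; no step beyond the scatter is expected, in either direction. Compound 3 is therefore estimated at 2500 nM, range 800 nM to 8000 nM, meaning an expected step of no change at the digits printed from compound 2 to compound 3 (within the scatter).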

Compound 3, half-maximal inhibitory concentration: 1400 nM
The estimate for compound 3 lay 1.8-fold (0.25 log units) above the measured number; measured number inside the range.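

In this assay, hept-1-en-1-yl in place of heptyl gives a 1.8-fold lower number from compound 2 to compound 3 (0.25 log units; within the scatter), so the second cis double bond cannot be told apart from the single-alkene chain of compound 2. Set against the hydroxylated chain, hept-1-en-1-yl in place of 1-hydroxyheptyl gives an at least 7.1-fold lower number from compound 1 to compound 3 (0.85 log units; beyond the scatter). That step has a lower bound only, resting on a limit rather than a number: the limit of > 10000 nM in this assay, at which 1 of the 3 values shown sits.

Open, from the compounds shown here alone, is how a trans double bond, a triple bond or a longer chain would read at this place. Also open, going by these compounds, is whether a third cis double bond would separate from compound 3 beyond the scatter.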